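A few compounds are considered here, and "the series" means these few. Any claim that something is new, unique, unknown or untested is made for them only; others in the source may bear on it.

Compound 1, `CCCCC/N=C(\NC#N)Nc1cccnc1`, is the starting point of this step. In a functional assay on the whole organism (blood, strain Wistar-Okamoto) with Rattus norvegicus as the target, with a stated time of 5 days (on this read-out lower numbers stand for an effect already at smaller amounts and higher numbers for an effect only at larger amounts of compound), compound 1 gives 20 mg/kg. Compound 3, `N#CN/C(=N\C1CCCC1)Nc1cccnc1`, gives 20 mg/kg in this assay, so compound 1 stands level with compound 3 at the digits shown, and the change no change at the digits printed from compound 1 to compound 3 (within the scatter) lies within the scatter. Compound 2, `CCCCC(CC)C/N=C(\NC#N)Nc1cccnc1`, reaches only a limit of the assay, > 50 mg/kg, and no number is given for it.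

The compound not yet measured is compound 4, `CC(C)C(C)(C)/N=C(\NC#N)Nc1cccnc1`. It differs from compound 1 in one place: 1,1,2-trimethylpropyl in place of pentyl on a double-bonded nitrogen. For the measured compounds named here, only one measured step bears on it, the exchange of pentyl for cyclopentyl on the same nitrogen, which left the read-out unchanged within the scatter. Against that stands the limit of > 50 mg/kg in this assay, at which 1 of the 3 values shown sits, seen for compound 2, which also carries a larger group on that nitrogen. Compound 4 is therefore expected to give about 30 mg/kg, between 15 mg/kg and 50 mg/kg, a step of a 1.5-fold higher number from compound 1 to compound 4 (0.18 log units; within the scatter) that is expected to reach at most the edge of the scatter, with a real chance that only a limit is reported.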

Compound 4, minimum effective dose: 1 mg/kg
For compound 4 the middle estimate is 30-fold (1.48 log units) above the measured one, and the stated range ends above it.
By their numbers in this assay, from the lowest: compound 4; then compounds 1 and 3 (each within the scatter of the next). At a limit, above all of these: compound 2.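

For the compounds shown here, at the double-bonded nitrogen, the earlier compounds showed only an exchange that left the read-out in place, whereas in this assay the 1,1,2-trimethylpropyl group brings a 20-fold lower number from compound 1 to compound 4 (1.30 log units; beyond the scatter) and a 20-fold lower number from compound 3 to compound 4 (1.30 log units; beyond the scatter). This position therefore responds strongly to the group it carries, and the choice of group can matter far more than the exchange of pentyl for cyclopentyl suggested. Compound 2, which also carries a larger group on that nitrogen, remains at a limit of the assay, so a larger group does not in itself bring the number down: the limit of > 50 mg/kg in this assay, at which 1 of the 4 values shown sits.

The compounds shown leave open whether a smaller branched group such as tert-butyl, or a ring-bearing group such as 1-methylcyclopentyl, would reach the level of compound 4. Going by these compounds, the core stays the same throughout, so it also remains open whether the gain from 1,1,2-trimethylpropyl would hold on a different core.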